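This account rests on a few compounds, and the source may have more. Where it says the series, first, only, none or still open, it means among the compounds named here.

For the measured compounds named here, in an ADME assay on Vero cells (Chlorocebus sabaeus) for cytotoxicity, read by CellTiter-Glo and ATP content, with a stated time of 72 h (on this read-out higher numbers stand for lower toxicity in this test and lower numbers for higher toxicity in this test), compound 3 `Nc1c(C2=NCCN2)cnn1-c1ccc(Cl)c(Cl)c1` gives 244000 nM, the only value so far that is not a limit. Compound 1 `Nc1c(C2=NCCN2)cnn1-c1ccccc1` reads > 500000 nM, which is a limit. Compound 2 `Nc1c(C2=NCCN2)cnn1-c1cccc(Cl)c1` reads > 500000 nM, also a limit. Compound 4 `Nc1c(C2=NCCN2)cnn1-c1ccc(Cl)cc1` follows from compound 3 by hydrogen in place of chloro on an aromatic carbon. The measured steps offer a step that the two limits leave unreadable from compound 1 to compound 2, which gives no size, and an at least 2.0-fold lower number from compound 2 to compound 3 (0.31 log units; beyond the scatter), which is the usable precedent. Taking off a chloro is therefore expected to give a modest move to a higher number in this assay, and a reading at the limit of > 500000 nM in this assay, at which 2 of the 3 values shown sit, is a likely outcome. The expected change is a 2.0-fold higher number from compound 3 to compound 4 (0.31 log units; beyond the scatter). Compound 4 is estimated at 500000 nM, with an expected range of 260000 nM to 900000 nM.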

Compound 4, half-maximal cytotoxic concentration: > 500000 nM
Compound 4: no number, only a limit; the forecaster's own chance of this, stated with the estimate: 55%; the middle value sits exactly at the limit.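

In this assay, the chloro that is ortho to a chloro group matters on this ring, since replacing it with hydrogen gives an at least 2.0-fold higher number from compound 3 to compound 4 (0.31 log units; beyond the scatter). For the compounds shown here, removing either chloro of compound 3 now ends at a limit, so a measurable number is seen only with both chloro groups present. The series mostly sits at a ceiling: the limit of > 500000 nM in this assay, at which 3 of the 4 values shown sit.

Going by these compounds, the steps from compound 1 to compound 2 and to compound 4 cannot be read, so what a single chloro does remains open. Also open, on these data alone, is how a methoxy group or an amine on this aromatic carbon would read.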